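A few compounds are considered here, and "the series" means these few. Any claim that something is new, unique, unknown or untested is made for them only; others in the source may bear on it.

The measured compounds:

Compound 1, `CC(C)Nc1nc(NCc2ccco2)c2cc(Cl)ccc2n1`, gives 170 10^-6 cm/s.
Compound 2, `CC(C)Nc1nc(NCc2ccco2)c2c(Cl)cccc2n1`, gives 169 10^-6 cm/s.
Compound 3, `Cc1ccc2nc(NC(C)C)nc(NCc3ccco3)c2c1`, gives 67.2 10^-6 cm/s.

All three were read in a physicochemical assay for permeability, using PAMPA, at pH 4; on this read-out higher numbers stand for higher permeability and lower numbers for lower permeability. Compound 1 and compound 2 share the same atoms joined differently; the difference between the two cores is not broken down here, and their two values lie within the scatter of each other. Compound 3 differs from compound 1 in one place, (methyl in place of chloro on an aromatic carbon), and that single exchange brought a 2.5-fold lower number from compound 1 to compound 3 (0.40 log units; beyond the scatter).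

Compound 4, `Cc1cccc2nc(NC(C)C)nc(NCc3ccco3)c12`, has not yet been measured in this assay. It differs from compound 2 by methyl in place of chloro on an aromatic carbon. Within the data shown here, this is the same kind of change as the one from compound 1 to compound 3, but not the same change: in compound 3 the methyl stands meta to a fused ring and para to a fused ring, while in compound 4 it stands ortho to a fused ring and meta to a fused ring. Resting on the step from compound 1 to compound 3, the expected step is a 2.4-fold lower number from compound 2 to compound 4 (0.38 log units; beyond the scatter). Compound 4 is accordingly estimated at 70 10^-6 cm/s, with a likely range from 40 10^-6 cm/s to 125 10^-6 cm/s.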

Compound 4, apparent permeability: 45.9 10^-6 cm/s
Compound 4: the middle estimate sits 1.5-fold (0.18 log units) above what was measured; the measured number falls inside the stated range.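

Read in this assay, the exchange of chloro for methyl gave a 3.7-fold lower number from compound 2 to compound 4 (0.57 log units; beyond the scatter) on one core and a 2.5-fold lower number from compound 1 to compound 3 (0.40 log units; beyond the scatter) on the other, so both steps run in the same direction and both lie beyond the scatter. This shows that the direction of the change carried over to compound 4, where the methyl stands ortho to a fused ring and meta to a fused ring, but two pairs are too few to establish a rule for the series. It does not show whether the two steps truly differ in size, and nothing measured here bears on what sets the size of either step.

The compounds shown leave open how a methoxy group or a nitrile in the same place would read in this assay compared with chloro and methyl. They also leave open whether an amine or a longer chain elsewhere on the shared core would alter the step seen with this exchange.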